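Fluoro analogue of compound 1: expected maximal response

A few compounds are considered here, and "the series" means these few. Any claim that something is new, unique, unknown or untested is made for them only; others in the source may bear on it.

Measured so far:
Compound 1 `CCCCn1ccc(-c2ccc(Oc3ccnc(C)c3)cc2)c(C#N)c1=O` gives 243% in a functional assay on CHO cells for positive allosteric modulation of metabotropic glutamate receptor 2 (Homo sapiens), read by scintillation counting and GTPgammaS binding, with a stated time of 30 min; a higher number here means a larger maximal response, a lower number a smaller maximal response.
Compound 2 `CCCCn1ccc(-c2ccc(Oc3ccnc(C)c3)c(Cl)c2)c(C#N)c1=O` gives 245% in this assay.

Compound 1 stands lowest of the two numbers in this assay, its nearest neighbour being compound 2, which lies within the scatter of it. Compound 3 `CCCCn1ccc(-c2ccc(Oc3ccnc(C)c3)cc2F)c(C#N)c1=O` has not yet been measured. It differs from compound 1 by fluoro in place of hydrogen on an aromatic carbon. Among the measured compounds shown here, the one measured step that bears on this change is the halogen for hydrogen on the same core, a number 2 percentage points higher from compound 1 to compound 2 (within the scatter), which stayed within the scatter. On that basis no step beyond the scatter is expected for the fluoro analogue either, in neither direction. For compound 3 the expected value in this assay is 243%, with a range from 215% to 275%. The expected step is thus no change at the digits printed from compound 1 to compound 3 (within the scatter), essentially flat.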

Compound 3, largest response reached (Emax), in percent of the reference or control that the assay uses: 232%
Compound 3: middle estimate off by 11 percentage points, on the high side; measured number inside the range.
By their numbers in this assay, from the lowest: compound 3; then compounds 1 and 2 (each within the scatter of the next).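

In this assay, among the compounds shown here, the step of a number 11 percentage points lower from compound 1 to compound 3 (beyond the scatter) is the first to pass the scatter, so a fluoro in place of hydrogen on this aromatic carbon, ortho to a large group and meta to the (2-methylpyridin-4-yl)oxy group, is not silent, although the loss is modest. For the compounds shown here, the only earlier step, the chloro change a number 2 percentage points higher from compound 1 to compound 2 (within the scatter), stayed within the scatter and gave no sign of any such sensitivity on this ring. No data at hand account for the fluoro step.

From the compounds shown here alone, whether methyl, methoxy or chloro on this same carbon would give a similar step remains open, so the loss cannot yet be assigned to this position or to fluoro itself. Also open, going by these compounds, is how fluoro behaves on the carbon that carries chloro in compound 2.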